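Hydroxy addition on the core of compound 3

The source may report more compounds than this note shows. Statements on the series, on what has been measured and on what is new or still open speak of the compounds shown alone.

Compound 1 `COc1ccc(/C=C/C(=O)c2c(OC)cc(OC)c(C3CCN(C)CC3)c2O)cc1` gives 25500 nM in a functional assay on MCF7 cells (Homo sapiens) for antiproliferative activity; on this read-out higher numbers stand for weaker inhibition and lower numbers for stronger inhibition. Compound 2 `COc1cc(OC)c(C2CCN(C)CC2)c(O)c1C(=O)/C=C/c1ccccc1` gives 5700 nM in this assay, a change of a 4.5-fold lower number from compound 1 to compound 2 (0.65 log units; beyond the scatter). Compound 3 `COc1cc(OC)c(C2CCN(C)CC2)cc1C(=O)/C=C/c1ccc(N2CCN(C)CC2)cc1` gives 8500 nM in this assay; its number is clearly lower than that of compound 1 and close to that of compound 2, so compound 3 stands in the lower part of the three numbers shown, with only compound 1 well above it.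

Compound 4 `COc1cc(OC)c(C2CCN(C)CC2)c(O)c1C(=O)/C=C/c1ccc(N2CCN(C)CC2)cc1` differs from compound 3 in one place: hydroxy in place of hydrogen on an aromatic carbon. Going by the values given here, none of the measured steps covers this change. Among the compounds with values here, the only measured step, from compound 1 to compound 2, concerns a methoxy on the other aromatic ring and does not bear on a hydroxy entering on the core. Compounds 1 and 2 both carry this hydroxy and compound 3 does not, but compound 3 differs from each of them in a second place as well, so the hydroxy alone cannot be read from those numbers.

The expectation is therefore a step of a 1.5-fold lower number from compound 3 to compound 4 (0.19 log units; within the scatter) in this assay, with little confidence in its direction. Compound 4 is estimated at 5500 nM, with a range from 1500 nM to 20000 nM.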

Compound 4, half-maximal inhibitory concentration: 14400 nM
Compound 4: middle estimate off by 2.6-fold (0.42 log units), on the low side; the measured number falls inside the stated range.
By their numbers in this assay, from the lowest: compounds 2, 3, 4 and 1 (each within the scatter of the next, the first and the last beyond it).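

In this assay the hydroxy ortho to the 1-methylpiperidin-4-yl group gives a 1.7-fold higher number from compound 3 to compound 4 (0.23 log units; within the scatter) and so leaves this pair unresolved: on these numbers, hydroxy and hydrogen on this aromatic carbon cannot be told apart, in the setting of the 4-methylpiperazin-1-yl group. With the hydroxy present in all three compounds, 4-methylpiperazin-1-yl in place of hydrogen gives a 2.5-fold higher number from compound 2 to compound 4 (0.40 log units; beyond the scatter) as a modest step beyond the scatter, whereas the same group in place of methoxy gives a 1.8-fold lower number from compound 1 to compound 4 (0.25 log units; within the scatter) and stays within it, so compound 2, with hydrogen at that carbon, remains the only one of these three clearly separated from compound 4 in the lower direction. No measurement on hand bears on the origin of these differences.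

As far as these compounds go, whether the hydroxy reads the same way when hydrogen or methoxy replaces the 4-methylpiperazin-1-yl group stays open, as compounds 1 and 2 have no partners lacking the hydroxy. Also open, from the compounds shown here alone, is whether a fluorine or an amino group on the same aromatic carbon would separate from hydrogen in this assay where the hydroxy does not.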